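CCR4 binding series: amine side chain trimmed to isopropyl

This account rests on a few compounds, and the source may have more. Where it says the series, first, only, none or still open, it means among the compounds named here.

Measured compounds:
- compound 1 `c1ccc2c(NC3CCCCCC3)nc(N3CCC(N4CCCC4)CC3)nc2c1`: 0%
- compound 2 `COc1cc2nc(NCCN3CCCCC3)nc(NC3CCCCCC3)c2cc1OC`: 18%

In an in vitro assay on B300-19 cells for displacement of a labelled ligand from C-C chemokine receptor type 4 (Homo sapiens), tested at 1 uM (on this read-out higher numbers stand for more inhibition at the one concentration tested (going by the name of the read-out) and lower numbers for less inhibition), compound 2 gives 18%, the highest of the two numbers in hand; in this assay compound 1 gives 0%, a gap beyond the usual scatter. Both numbers sit at the low end of the read-out, so the series as a whole shows little displacement at the tested concentration.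

Compound 3 `COc1cc2nc(NC(C)C)nc(NC3CCCCCC3)c2cc1OC` is the next compound, not yet measured. It differs from compound 2 in one place: isopropyl in place of 2-(piperidin-1-yl)ethyl on a nitrogen on an aromatic ring

Among the measured compounds shown here, no step between two measured compounds covers this change, so no measured size can be borrowed for it. Because compound 2 gives only 18%, there is little room for a large drop, and a rise beyond the scatter has no support in the two numbers in hand. The expectation is a small downward step, a number 10 percentage points lower from compound 2 to compound 3 (within the scatter), most likely within the scatter. For compound 3 the estimated value in this assay is 8%, with a range from 0% to 22%.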

Compound 3, a percentage reported as inhibition, at one concentration (the size of the read-out at that concentration, not a potency): 6%
The estimate for compound 3 lay 2 percentage points above the measured number; measured number inside the range.
By their numbers in this assay, from the lowest: compounds 1 and 3 (each within the scatter of the next); then compound 2.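

In this assay, among the compounds shown here, isopropyl in place of 2-(piperidin-1-yl)ethyl on a nitrogen on an aromatic ring gives a number 12 percentage points lower from compound 2 to compound 3 (beyond the scatter), the first step read across a single change. The group on this nitrogen therefore has a measurable bearing on the read-out, although the effect is modest and both numbers remain low, with compound 2 at 18% and compound 3 at 6%. The change removes the six-membered non-aromatic ring, its hetero atom and the chain together, and nothing available gives a reason for the step or assigns it to any one of these parts.

Still open, as far as these compounds go, is which part of the side chain carries the step: 2-(dimethylamino)ethyl would test the chain and amine without the ring, while 2-cyclohexylethyl would test the chain and ring without the amine nitrogen. Also open, from the compounds shown here alone, is whether a longer chain, such as 3-(piperidin-1-yl)propyl, or a different amine, such as 2-(morpholin-4-yl)ethyl, would lift the number in this assay beyond that of compound 2.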